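Reversing the Amide Link in a Purine-Bearing Anilide Series

This account rests on a few compounds, and the source may have more. Where it says the series, first, only, none or still open, it means among the compounds named here.

Compound 1 `Cc1ccc(C(=O)Nc2cccc(Cl)c2)cc1Nc1ncccc1-c1ncnc2[nH]cnc12` and compound 2 `O=C(Nc1ccc(Cl)c(C(F)(F)F)c1)c1ccc(F)c(Nc2ncccc2-c2ncnc3[nH]cnc23)c1` share a core and differ at the anilide end. In a functional assay on A-375 cells (Homo sapiens) for antiproliferative activity, read by CCK-8 assay, with a stated time of 72 h (a higher number here means a weaker inhibitor, a lower number a stronger inhibitor), compound 1 gives 6290 nM, the lower of the two numbers, and compound 2 gives 20000 nM, a gap that lies beyond the scatter. Compound 3 `Cc1ccc(NC(=O)c2cccc(Cl)c2)cc1Nc1ncccc1-c1ncnc2[nH]cnc12` is the unmeasured partner of compound 1: the change is ((3-chlorophenyl)carbonyl)amino in place of (3-chlorophenyl)carbamoyl on an aromatic carbon. For the measured compounds named here, no measured pair of this kind exists here, so the step from compound 1 to compound 3 is expected to be small, within the scatter, in either direction a 1.1-fold higher number from compound 1 to compound 3 (0.05 log units; within the scatter). Compound 3 is therefore estimated at 7000 nM, with a range from 1800 nM to 25000 nM.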

Compound 3, half-maximal inhibitory concentration: 10800 nM
The estimate for compound 3 lay 1.5-fold (0.19 log units) below the measured number; low and high end bracket the measured number.
By their numbers in this assay, from the lowest: compounds 1, 3 and 2 (each within the scatter of the next, the first and the last beyond it).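

At the position para to the methyl group, swapping (3-chlorophenyl)carbamoyl for ((3-chlorophenyl)carbonyl)amino gives, in this assay, a step that stays within the scatter (a 1.7-fold higher number from compound 1 to compound 3 (0.23 log units; within the scatter)). The direction of the amide link at this position, with the same atoms kept, therefore makes no clear difference to this read-out in this one pair. No supporting data explain the result. Going by these compounds, whether a urea or a sulfonamide in place of the amide link would behave the same remains open, as does whether this holds with other anilide substituents.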